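A Hydroxypropyl Sulfonamide Variant of Compound 1

The source may report more compounds than this note shows. Statements on the series, on what has been measured and on what is new or still open speak of the compounds shown alone.

Compound 1, `CCC1C(=O)N(C)c2cnc(Nc3ccc(S(=O)(=O)NCC(C)C)cc3)nc2N1c1ccn(C)n1`, gives 311 nM in an assay for inhibition of serine/threonine-protein kinase PLK2 (Homo sapiens), read by FRET and Z'-LYTE, with a stated time of 1 h; on this read-out higher numbers stand for weaker inhibition and lower numbers for stronger inhibition.
Compound 2, `CCCNC(=O)c1ccc2c(ccn2-c2ncc3c(n2)N(C2CCCC2)[C@H](CC)C(=O)N3C)c1`, gives 11.4 nM in this assay.
Compound 3, `CC[C@@H]1C(=O)N(C)c2cnc(Nc3ccc(S(=O)(=O)NC4CCCC4)cc3)nc2N1C1CCCC1`, gives 23.9 nM in this assay.

Of the three measured compounds, compound 1 stands at the highest number, which on this read-out means the weakest inhibition. Compound 3 sits well below it, beyond the scatter of the measurement, and compound 2 lower still. Both of those compounds differ from compound 1 in several places at once, so none of these gaps can be read as the effect of a single change.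

The new compound, compound 4, `CCC1C(=O)N(C)c2cnc(Nc3ccc(S(=O)(=O)NCCCO)cc3)nc2N1c1ccn(C)n1`, differs from compound 1 in one place only: 2-hydroxyethyl in place of isopropyl on a saturated chain carbon bound to a sulfonamide nitrogen. The shared core and the sulfonamide-bearing ring remain untouched; only the chain on the sulfonamide nitrogen is exchanged, isobutyl giving way to 3-hydroxypropyl.

For the measured compounds named here, no measured pair here isolates a change of this kind, so there is no direct guide to its size. The chain sits at the outer end of the molecule, away from the core, and the expectation is that the step from compound 1 to compound 4 stays within the scatter, with no clear direction: a 1.0-fold lower number from compound 1 to compound 4 (0.02 log units; within the scatter). Compound 4 is therefore estimated at 300 nM, with a range from 120 nM to 800 nM.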

Compound 4, half-maximal inhibitory concentration: 192 nM
Estimate against measurement, compound 4: 1.6-fold (0.19 log units) above; measured number inside the range.
By their numbers in this assay, from the lowest: compound 2; then compound 3; then compounds 4 and 1 (each within the scatter of the next).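

For the compounds shown here, this is the one comparison in the set that isolates a single change. With the shared core and the sulfonamide-bearing ring held fixed, 3-hydroxypropyl in place of isobutyl gives a 1.6-fold lower number from compound 1 to compound 4 (0.21 log units; within the scatter) in this assay, so the two numbers cannot be told apart. On this scaffold, then, a chain with one hydrogen-bond donor and one hydrogen-bond acceptor reads the same as a chain with neither, and nothing available explains why these two chains give such similar numbers.

As far as these compounds go, one pair cannot show how far this holds, so it remains open whether an amine or a carboxylic acid at the end of the chain, or a longer chain, would also stay within the scatter of compound 1. From the compounds shown here alone, it also remains open whether 3-hydroxypropyl would read the same on the sulfonamide of compound 3, where the rest of the molecule differs and the number in this assay already lies much lower.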